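Triazine Herbicides: Swapping an Ethylamino for Diisopropylamino

The source may hold more compounds than are shown below. What is called first, only, known or untested is meant among the compounds shown, and "the series" means these compounds.

Measured so far:
Compound 1, `CCNc1nc(Cl)nc(N[C@H](C)c2ccccc2)n1`: 2690 nM
Compound 2, `CC(C)Nc1nc(Cl)nc(N[C@@H](C)c2ccccc2)n1`: 11000 nM

Of the compounds shown here, two have been measured in an ADME assay on the whole organism for inhibition, with Echinochloa crus-galli var. formosensis as the target, with a stated time of 4 days; a lower number here means a stronger inhibitor, a higher number a weaker inhibitor. Compound 1, with the structure `CCNc1nc(Cl)nc(N[C@H](C)c2ccccc2)n1`, gives 2690 nM. Compound 2, with the structure `CC(C)Nc1nc(Cl)nc(N[C@@H](C)c2ccccc2)n1`, gives 11000 nM. Of the two numbers, compound 1 has the lower one, and the gap to compound 2 lies beyond the scatter of repeated measurements, so compound 1 stands as the stronger inhibitor of the pair.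

The next compound, compound 3, has the structure `CC(C)N(c1nc(Cl)nc(N[C@H](C)c2ccccc2)n1)C(C)C`. Relative to compound 1 the change is diisopropylamino in place of ethylamino on an aromatic carbon. Among the compounds with values here, no step between two measured compounds matches this change, so the expectation rests on the two values alone. The account expects a step of a 3.7-fold higher number from compound 1 to compound 3 (0.57 log units; beyond the scatter) in this assay, towards a weaker inhibitor, beyond the usual scatter. For compound 3 the estimate is 10000 nM, with a range from 3000 nM to 40000 nM.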

Compound 3, half-maximal inhibitory concentration: 6610 nM
Beside the measured number, compound 3's estimate is 1.5-fold (0.18 log units) above it, and the stated range covers the measured number.
By their numbers in this assay, from the lowest: compound 1; then compounds 3 and 2 (each within the scatter of the next).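

In this assay, within the data shown here, this is the first reading of a change at this place alone, on the aromatic carbon between two ring nitrogen atoms, with the rest of compound 1 left as it stands: a 2.5-fold higher number from compound 1 to compound 3 (0.39 log units; beyond the scatter) is a modest step towards a weaker inhibitor, though it lies beyond the scatter. The group grows from ethylamino, with 3 heavy atoms and 1 hydrogen-bond donor, to diisopropylamino, with 7 heavy atoms and 0 hydrogen-bond donors, and compound 3 still gives a measurable half-maximal inhibitory concentration. Nothing measured here accounts for the size or the direction of this step, and a single step cannot separate the larger group from the missing donor.

On these data alone, what remains open is how the values run between these two groups: whether dimethylamino or a morpholine ring at this place would read closer to compound 1 or to compound 3. As far as these compounds go, it is also open whether a cyclopropylamino group or a longer chain such as n-butylamino, each keeping the amine hydrogen, would hold the number of compound 1 or move it in the same direction.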